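This account rests on a few compounds, and the source may have more. Where it says the series, first, only, none or still open, it means among the compounds named here.

Compounds measured so far in a functional assay on CHO cells for antagonist activity at C-X-C chemokine receptor type 3 (Homo sapiens), read by GTPgammaS binding; on this read-out lower numbers stand for stronger inhibition and higher numbers for weaker inhibition:
- compound 1 `CC1(C)[C@H]2CC=C(CN3CCC(NC(=O)Nc4ccccc4)CC3)[C@@H]1C2` gives 2000 nM
- compound 2 `CC1(C)[C@H]2CC=C(CN3CCC(NC(=O)Nc4cc(F)cc(F)c4)CC3)[C@@H]1C2` gives 171 nM

Within the data shown here, compound 2 has the lowest number of the two; its nearest neighbour is compound 1, and the one step recorded between them, a 12-fold lower number from compound 1 to compound 2 (1.07 log units; beyond the scatter), lies beyond the scatter and is large. Compound 3 `COc1cccc(NC(=O)NC2CCN(CC3=CC[C@H]4C[C@@H]3C4(C)C)CC2)c1` differs from compound 2 in one place: 3-methoxyphenyl in place of 3,5-difluorophenyl on an amide-type nitrogen.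

Among the measured compounds shown here, the only measured step bears on this change indirectly. It shows that the group on the amide-type nitrogen matters a great deal in this assay, since going from phenyl to 3,5-difluorophenyl gave the large drop just named. For the measured compounds named here, nothing among the measured compounds shows how a 3-methoxyphenyl in that position behaves, so the direction of the step is open; the data allow that compound 3 falls anywhere between the two measured numbers or near either of them. On balance the expected step is an increase in the number estimated as a 3.5-fold higher number from compound 2 to compound 3 (0.55 log units; beyond the scatter). For compound 3 the estimate is 600 nM, with a plausible range from 150 nM to 2500 nM.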

Compound 3, inhibition constant: 429 nM
For compound 3 the middle estimate is 1.4-fold (0.15 log units) above the measured one; the range from low to high includes it.
By their numbers in this assay, from the lowest: compound 2; then compound 3; then compound 1.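

In this assay, the lower number seen with the 3,5-difluorophenyl group is not unique to that group: placing a methoxy on the aromatic ring of compound 1 also gives a gain, a 4.7-fold lower number from compound 1 to compound 3 (0.67 log units; beyond the scatter). The two substituted rings are not interchangeable on the amide-type nitrogen, however, since the exchange of 3,5-difluorophenyl for 3-methoxyphenyl gives a 2.5-fold higher number from compound 2 to compound 3 (0.40 log units; beyond the scatter), so the fluorine-bearing ring keeps the lowest number of the three compounds. No measurement at hand accounts for this difference between the groups.

Going by these compounds, it remains open whether fluorine and methoxy would add up on one ring, and how a single fluorine, a chlorine, a trifluoromethyl, a nitrile or a dimethylamino group would rank against the 3,5-difluorophenyl and 3-methoxyphenyl groups on the same amide-type nitrogen. On these data alone, all three compounds also share one core, so it is equally open whether this order of the aromatic groups would hold if that core were changed, for example with a plain benzyl group on the ring nitrogen.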